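Compound 3: anilino in place of ethoxy

The compounds below may be only part of what the source reports. "The series", "measured", "known", "first", "only" and "open" are said of these compounds alone.

Compound 1 `COc1c(N2CCN(CCC(C)=O)C(C)C2)c(F)cc2c(=O)c(C(=O)O)cn(C3CC3)c12`: 9.84 ug/mL
Compound 2 `CCO/N=C(\C)CN1CCN(c2c(F)cc3c(=O)c(C(=O)O)cn(C4CC4)c3c2OC)CC1C`: 31.3 ug/mL

In an ADME assay on Vero cells (Chlorocebus sabaeus) for cytotoxicity, read by MTT assay, with a stated time of 72 h (on this read-out lower numbers stand for higher toxicity in this test and higher numbers for lower toxicity in this test), compound 2 gives 31.3 ug/mL, the higher of the two numbers. Compound 3 `COc1c(N2CCN(C/C(C)=N/Nc3ccccc3)C(C)C2)c(F)cc2c(=O)c(C(=O)O)cn(C3CC3)c12` brings anilino in place of ethoxy on a double-bonded nitrogen. For the measured compounds named here, the only measured step, a 3.2-fold higher number from compound 1 to compound 2 (0.50 log units; beyond the scatter), is modest and involves no anilino group, so it bears on this change only as a guide to size. The expected step is a 1.6-fold lower number from compound 2 to compound 3 (0.19 log units; within the scatter), leaning towards a lower number, with its direction uncertain. The estimated value for compound 3 is 20 ug/mL, with an expected range of 7 ug/mL to 60 ug/mL.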

Compound 3, half-maximal cytotoxic concentration: 11.1 ug/mL
For compound 3 the middle estimate is 1.8-fold (0.26 log units) above the measured one; the measured number falls inside the stated range.
By their numbers in this assay, from the lowest: compounds 1 and 3 (each within the scatter of the next); then compound 2.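

In this assay, the group on the double-bonded nitrogen affects the number: anilino in place of ethoxy gives a step beyond the scatter (a 2.8-fold lower number from compound 2 to compound 3 (0.45 log units; beyond the scatter)). The side chain of compound 3 and the group it replaces in compound 1 are not separated by this read-out (a 1.1-fold higher number from compound 1 to compound 3 (0.05 log units; within the scatter)). No measurement here gives a reason for either step.

The compounds shown do not separate the effect of the aromatic ring from that of the added nitrogen and its hydrogen-bond donor. Benzyloxy on the double-bonded nitrogen would carry the ring without that nitrogen.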